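The compounds below may be only part of what the source reports. "The series", "measured", "known", "first", "only" and "open" are said of these compounds alone.

Compounds measured in an assay on CHO cells for displacement of a labelled ligand from 5-hydroxytryptamine receptor 7 (Homo sapiens); a lower number here means a stronger inhibitor, a higher number a weaker inhibitor:
compound 1 `CCC1(CCCCN2CCN(c3ccc(Cl)cc3)CC2)C(=O)Nc2ccccc21` — 0.38 nM; 0.38 nM (2 entries)
compound 2 `CCC1(CCCCN2CCN(c3ccccc3OC)CC2)C(=O)Nc2ccccc21` — 5.38 nM
compound 3 `CCC1(CCCCN2CCN(c3ccc(F)cc3)CC2)C(=O)Nc2ccccc21` — 0.43 nM

Compound 3 holds the lowest of the two single numbers given; its nearest neighbour is compound 2, and the step of a 13-fold lower number from compound 2 to compound 3 (1.10 log units; beyond the scatter) lies beyond the scatter. Compound 1, with two entries, stands close to compound 3 on the values shown. Compound 4 `CCC1(CCCCN2CCN(c3ccc(F)c(Cl)c3)CC2)C(=O)Nc2ccccc21` differs from compound 3 by chloro in place of hydrogen on an aromatic carbon. Among the measured compounds shown here, the one measured step, from compound 2 to compound 3, exchanges the whole aryl group and so bears only loosely on this change; no step adding a second substituent to the ring is available. The expected step is a 1.3-fold higher number from compound 3 to compound 4 (0.11 log units; within the scatter), small and not clearly beyond the scatter. Compound 4 is expected to give 0.55 nM, with a range from 0.15 nM to 2 nM.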

Compound 4, inhibition constant: 0.6 nM
Estimate against measurement, compound 4: 1.1-fold (0.04 log units) below, and the stated range covers the measured number.
By their numbers in this assay, from the lowest: compounds 3 and 4 (each within the scatter of the next); then compound 2.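

In this assay, chloro in place of hydrogen on the six-membered aromatic ring, ortho to a fluoro group, leaves the number within the scatter (a 1.4-fold higher number from compound 3 to compound 4 (0.14 log units; within the scatter)). Among the compounds shown here, this is the first sight of a second substituent on this ring, and compound 4 keeps a clear gap from the 2-methoxyphenyl compound (a 9.0-fold lower number from compound 2 to compound 4 (0.95 log units; beyond the scatter)). Nothing shown offers a reason for either step. As far as these compounds go, whether methyl, methoxy or an amine at this position would be accepted as chloro is stays open, as does whether this change holds with a longer chain in the shared core.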